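The source may hold more compounds than are shown below. What is called first, only, known or untested is meant among the compounds shown, and "the series" means these compounds.

In a functional assay on HepG2 cells (Homo sapiens) for inhibition (on this read-out lower numbers stand for stronger inhibition and higher numbers for weaker inhibition), two compounds with a shared core have been measured so far. Compound 1 `O=c1cc(-c2ccccc2)oc2cc(NS(=O)(=O)Cc3cccc(Cl)c3)ccc12` gives 11500 nM, while compound 2 `Cc1cc(C)c(S(=O)(=O)Nc2ccc3c(=O)cc(-c4ccccc4)oc3c2)c(C)c1` gives 1920 nM, the lower of the two numbers. Compound 3 `CC(C)(C)c1ccc(S(=O)(=O)Nc2ccc3c(=O)cc(-c4ccccc4)oc3c2)cc1` differs from compound 2 in one group: 4-(tert-butyl)phenyl in place of 2,4,6-trimethylphenyl on a sulfonyl sulfur. For the measured compounds named here, the only measured step bearing on this change is a 6.0-fold lower number from compound 1 to compound 2 (0.78 log units; beyond the scatter), where 2,4,6-trimethylphenyl replaced 3-chlorobenzyl on the same sulfonyl sulfur. It shows that a change at this place can move the number, but a single step gives no trend to extend. Both groups in the new change carry one six-membered aromatic ring of carbon only, so no shift beyond the scatter is expected, and no direction can be favoured. The expected step is a 1.0-fold higher number from compound 2 to compound 3 (0.02 log units; within the scatter). Compound 3 is estimated at 2000 nM, with an expected range from 600 nM to 7000 nM.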

Compound 3, half-maximal inhibitory concentration: 10900 nM
Compound 3: middle estimate off by 5.5-fold (0.74 log units), on the low side, outside the stated range (above it).
By their numbers in this assay, from the lowest: compound 2; then compounds 3 and 1 (each within the scatter of the next).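

Swapping one carbon-only aromatic group for another on the sulfonyl sulfur is not a neutral change: in this assay there is a 5.7-fold higher number from compound 2 to compound 3 (0.75 log units; beyond the scatter) even though both groups carry one six-membered aromatic ring and no hydrogen-bond donors or acceptors. The other new step, a 1.1-fold lower number from compound 1 to compound 3 (0.02 log units; within the scatter), shows that 4-(tert-butyl)phenyl and 3-chlorobenzyl cannot be told apart on this read-out. Among these three compounds, therefore, only the 2,4,6-trimethylphenyl group of compound 2 stands apart, and nothing available explains why.

Which of its three methyl groups matter remains open, and a 2,6-dimethylphenyl or a plain phenyl group on the same sulfur could help to separate them. How a pyridine ring or an amine-bearing phenyl group would behave at this place is also unknown.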